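Moving the hydroxyl of compound 1 around its aryl ring

This account rests on a few compounds, and the source may have more. Where it says the series, first, only, none or still open, it means among the compounds named here.

Compound 1 `CCCSc1nc(N/N=C(\C)c2ccc(O)cc2)c2nnn(Cc3ccccc3)c2n1` gives 16700 nM in a functional assay on MGC-803 cells (Homo sapiens) for antiproliferative activity, read by MTT assay, with a stated time of 72 h (on this read-out higher numbers stand for weaker inhibition and lower numbers for stronger inhibition), the lowest of the numbers shown. Its nearest neighbour is compound 2 `CCCSc1nc(N/N=C(\C)c2ccc(OC)cc2)c2nnn(Cc3ccccc3)c2n1` at 44300 nM, a change of a 2.7-fold higher number from compound 1 to compound 2 (0.42 log units; beyond the scatter). Compound 3 `CCCSc1nc(N/N=C/c2cccc(Cl)c2)c2nnn(Cc3ccccc3)c2n1` reaches only the limit of > 64000 nM in this assay, as noted by the limit of > 64000 nM in this assay, at which 1 of the 3 values shown sits. From compound 1 this amounts to an at least 3.8-fold higher number from compound 1 to compound 3 (0.58 log units; beyond the scatter). Compound 4 `CCCSc1nc(N/N=C(\C)c2ccccc2O)c2nnn(Cc3ccccc3)c2n1` differs from compound 1 by 2-hydroxyphenyl in place of 4-hydroxyphenyl on a carbon with a double bond to nitrogen. Both measured steps moved the number upward, yet neither relocates the hydroxyl on the ring, so the evidence bears only loosely. A modest rise in this assay is expected, a 1.6-fold higher number from compound 1 to compound 4 (0.19 log units; within the scatter). Compound 4 is therefore estimated at 26000 nM, within 9000 nM to 64000 nM.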

Compound 4, half-maximal inhibitory concentration: 2310 nM
Compound 4: the middle estimate sits 11-fold (1.05 log units) above what was measured, outside the stated range (below it).
By their numbers in this assay, from the lowest: compound 4; then compound 1; then compound 2. At a limit, above all of these: compound 3.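

In this assay, where the hydroxyl sits on the ring matters, as the two structures hold the same atoms joined differently: a 7.2-fold lower number from compound 1 to compound 4 (0.86 log units; beyond the scatter). 2-Hydroxyphenyl in place of 4-methoxyphenyl goes further, with a 19-fold lower number from compound 2 to compound 4 (1.28 log units; beyond the scatter). Compound 3 stands at a limit, > 64000 nM, so an at least 27-fold lower number from compound 3 to compound 4 (1.44 log units; beyond the scatter) marks only a bound.

Nothing measured here accounts for the gain from this move. As far as these compounds go, whether the hydroxyl of compound 4 can give way to an amine or a carboxylic acid with its number kept stays open.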